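Sulfonyl group exchange from compound 2 to compound 3

The source may hold more compounds than are shown below. What is called first, only, known or untested is meant among the compounds shown, and "the series" means these compounds.

In an in vivo ADME assay on the whole organism (strain Sprague-Dawley) for pharmacokinetics, with Rattus norvegicus as the target (a lower number here means that a smaller share of the oral dose reaches the circulation, a higher number that a larger share of the oral dose reaches the circulation), compound 2 `O=C1[C@@H](NS(=O)(=O)/C=C/c2ccc(Cl)s2)CCN1c1ccc(C2CCCN2)cc1F` gives 52%, the only exact figure so far. Compound 1 `CN[C@@H](C)c1ccc(N2CC[C@H](NS(=O)(=O)c3ccc4cc(Cl)ccc4c3)C2=O)c(F)c1`, which also bears 6-chloronaphthalen-2-yl on a sulfonyl sulfur, gives > 10%, and this is a limit of the assay, not a number. Compound 3 `O=C1[C@@H](NS(=O)(=O)c2ccc3cc(Cl)ccc3c2)CCN1c1ccc(C2CCCN2)cc1F` has 6-chloronaphthalen-2-yl in place of 2-(5-chlorothiophen-2-yl)ethenyl on a sulfonyl sulfur. For the measured compounds named here, no measured step covers this exchange, so the expectation is loose. A moderate fall is expected for the step of a number 12 percentage points lower from compound 2 to compound 3 (beyond the scatter), and it may stay within the scatter. For compound 3 the estimated value is 40%, with an expected range of 18% to 65%.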

Compound 3, oral bioavailability: 24%
Estimate against measurement, compound 3: 16 percentage points above, and the stated range covers the measured number.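

On the sulfonyl sulfur, 6-chloronaphthalen-2-yl in place of 2-(5-chlorothiophen-2-yl)ethenyl gives a readable change in this assay, namely a number 28 percentage points lower from compound 2 to compound 3 (beyond the scatter). This position therefore matters for the read-out with the pyrrolidin-2-yl group held constant. The step between compound 1 and compound 3 cannot be read, as compound 1 stands at a limit and not at a number: the limit of > 10% in this assay, at which 1 of the 3 values shown sits.

Going by these compounds, it remains open which part of the exchange carries the fall: the ethenyl link, the chlorothiophene or the second aromatic ring. On these data alone, how a plain phenyl group or a chain bearing an amine would read on this sulfonyl sulfur also remains open.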